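The compounds below may be only part of what the source reports. "The series", "measured", "known", "first", "only" and "open" are said of these compounds alone.

In a functional assay on SGC-7901 cells (Homo sapiens) for antiproliferative activity, read by MTT assay, with a stated time of 72 h (on this read-out lower numbers stand for stronger inhibition and higher numbers for weaker inhibition), compound 3 `COc1cc(-n2cnc3ccc(-c4ccc(Cl)cc4Cl)cc32)cc(OC)c1OC` gives > 10000 nM, which is a limit and not a number. Compound 1 `COc1cc(-n2cnc3ccc(-c4ccccc4Cl)cc32)cc(OC)c1OC` gives > 10000 nM, also a limit. Together they make up (the limit of > 10000 nM in this assay, at which 2 of the 3 values shown sit). Among the compounds with values here, compound 2 `COc1cc(-n2cnc3ccc(-c4ccc(C(F)(F)F)cc4)cc32)cc(OC)c1OC` gives 890 nM, the only true number so far.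

Compound 4 `COc1cccc(-c2ccc3ncn(-c4cc(OC)c(OC)c(OC)c4)c3c2)c1` carries 3-methoxyphenyl in place of 2,4-dichlorophenyl on an aromatic carbon. The nearest evidence is the exchange of this aryl group elsewhere in the series: an at least 11-fold lower number from compound 1 to compound 2 (1.05 log units; beyond the scatter) and an at least 11-fold higher number from compound 2 to compound 3 (1.05 log units; beyond the scatter), both large, while the chloro step is a step that the two limits leave unreadable from compound 1 to compound 3. With compound 2 as the guide through an at least 11-fold higher number from compound 2 to compound 3 (1.05 log units; beyond the scatter), a sizeable step to a lower number is expected in this assay, though probably not the full one. The expected change is an at least 4.0-fold lower number from compound 3 to compound 4 (0.60 log units; beyond the scatter). For compound 4 the estimated value is 2500 nM, with an expected range of 600 nM to 10000 nM.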

Compound 4, half-maximal inhibitory concentration: 3310 nM
Compound 4: middle estimate off by 1.3-fold (0.12 log units), on the low side, within the range that was stated.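

In this assay, a group other than 4-(trifluoromethyl)phenyl gives a true number at this aryl position on the shared core, with an at least 3.0-fold lower number from compound 3 to compound 4 (0.48 log units; beyond the scatter) and an at least 3.0-fold lower number from compound 1 to compound 4 (0.48 log units; beyond the scatter). The 3-methoxyphenyl group does not match 4-(trifluoromethyl)phenyl, with a 3.7-fold higher number from compound 2 to compound 4 (0.57 log units; beyond the scatter). Compound 1 and compound 3, the two chloro-bearing compounds, remain limits and not numbers: the limit of > 10000 nM in this assay, at which 2 of the 4 values shown sit.

On these data alone, it remains open whether the methoxy group reads the same from another place on the phenyl ring. As far as these compounds go, how an amine or a carboxylic acid on this phenyl ring would read is also open.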